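Chloro for Hydroxy on a Quinoline Selenide Chain

The compounds below may be only part of what the source reports. "The series", "measured", "known", "first", "only" and "open" are said of these compounds alone.

The study covers a small set of compounds sharing one core. Compound 1, `C#CCSc1cnc2ccccc2c1[Se]CC#CCCl`, was tested in a functional assay on SW707 cells (Homo sapiens) for antiproliferative activity, with a stated time of 72 h (on this read-out higher numbers stand for weaker inhibition and lower numbers for stronger inhibition), where compound 1 gives 3.2 ug/mL. Compound 2, `CSc1cnc2ccccc2c1[Se]CC#CCO`, carries a methylthio group and a 4-hydroxybut-2-yn-1-yl chain on the selenium; in this assay compound 2 gives 3.4 ug/mL. Among the compounds with values here, compound 2 stands at the top of the two numbers measured so far, yet its gap to compound 1 lies within the usual scatter, so the two values cannot be told apart. Compound 1 and compound 2 differ in two places. Within the data shown here, no single step between them can be read.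

Compound 3, `CSc1cnc2ccccc2c1[Se]CC#CCCl`, has not yet been measured. It differs from compound 2 in one place: chloro in place of hydroxy on a saturated chain carbon bound to a triple-bonded carbon. Compound 1 already carries the chloro group and sits within the scatter of compound 2, so the step of a 1.1-fold lower number from compound 2 to compound 3 (0.05 log units; within the scatter) is expected to be small and in no clear direction. Compound 3 is estimated to give 3 ug/mL, with a range from 1.5 ug/mL to 6 ug/mL.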

Compound 3, concentration for 50% inhibition: 3.2 ug/mL
For compound 3 the middle estimate is 1.1-fold (0.03 log units) below the measured one; the range from low to high includes it.
By their numbers in this assay, from the lowest: compounds 1, 3 and 2 (each within the scatter of the next).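

In this assay, chloro in place of hydroxy on a saturated chain carbon bound to a triple-bonded carbon can now be read as a single change, and it gives a 1.1-fold lower number from compound 2 to compound 3 (0.03 log units; within the scatter) with nothing else altered in the structure, so this read-out does not separate the two groups at this position. The second change that lay hidden in the pair of compound 1 and compound 2, hydrogen in place of ethynyl on a saturated chain carbon bound to a sulfur, can also be read alone, as no change at the digits printed from compound 1 to compound 3 (within the scatter) on the same read-out, which means that neither single step taken by itself moves the value beyond the scatter. The data at hand offer no independent measurement that could account for how closely these values agree.

The compounds shown place only hydroxy and chloro at the end of the 4-hydroxybut-2-yn-1-yl chain, so it remains open how an amine, a methoxy group or a carboxylic acid would read there. From the compounds shown here alone, a longer chain on the selenium, and a larger group than methylthio or its ethynyl-bearing counterpart on the sulfur, also remain open.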